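Working notes: methoxy in place of bromo on compound 3

This account rests on a few compounds, and the source may have more. Where it says the series, first, only, none or still open, it means among the compounds named here.

In a functional assay on NCI-H460 cells (Homo sapiens) for cytotoxicity, read by sulforhodamine B assay, with a stated time of 3 days (on this read-out lower numbers stand for stronger inhibition and higher numbers for weaker inhibition), compound 1 (`O=CC1C(=O)N(Cc2ccc(Cl)cc2)c2cc(Cl)ccc21`) gives 18200 nM and stands far from the other two measured compounds. Compound 2 (`OCc1cn(Cc2cccc(Br)c2)c2ccccc12`) gives 28 nM in the same test. Compound 3 (`OCc1cn(Cc2ccc(Br)cc2)c2ccccc12`) gives 31 nM and so lies within the scatter of compound 2 and beyond the scatter of compound 1.

Compound 4 (`COc1ccc(Cn2cc(CO)c3ccccc32)cc1`) has not yet been measured. It differs from compound 3 by methoxy in place of bromo on an aromatic carbon, para to a large group (methoxy in place of bromo on an aromatic carbon). Within the data shown here, no measured pair shows this change, so the data give no direct size for the step. Compound 4 keeps the core of compound 3 rather than the core of compound 1, so compound 3 at 31 nM is the starting point and compound 2 at 28 nM marks the same range. In this assay a small rise in the number is expected, at about the edge of the scatter, with no fall to the level of compound 1. The estimated step is a 1.9-fold higher number from compound 3 to compound 4 (0.29 log units; within the scatter) towards weaker inhibition. For compound 4 the expected value is 60 nM with an estimated range of 15 nM to 300 nM on this read-out.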

Compound 4, half-maximal inhibitory concentration: 79 nM
The estimate for compound 4 lay 1.3-fold (0.12 log units) below the measured number, within the range that was stated.
By their numbers in this assay, from the lowest: compounds 2 and 3 (each within the scatter of the next); then compound 4; then compound 1.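

Methoxy in place of bromo on an aromatic carbon, para to a large group, gives a 2.5-fold higher number from compound 3 to compound 4 (0.41 log units; beyond the scatter) in this assay, and this is the first change in one place that can be read in the series. The result shows that the group at this position does affect the read-out, although the step is only modest and rests on this single pair. Heavy atoms go from one to two and hydrogen-bond acceptors from none to one, but the step belongs to the exchange as a whole and does not show which of these differences matters, and no measurement available here explains the rise.

A single pair does not separate the effect of the added oxygen from that of the change in group, so an amine, a carboxylic acid or a longer alkoxy chain at the same place would be needed to show whether the higher number is particular to methoxy or extends to other replacements of bromo. On these data alone, whether methoxy in place of bromo on compound 2 gives a step of similar size also remains open.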